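Iodo for Chloro on the Aryl Group of Compound 2

The source may report more compounds than this note shows. Statements on the series, on what has been measured and on what is new or still open speak of the compounds shown alone.

Compound 1, `COc1ccc(-c2nc3c(=O)n(C)c(=O)n(C)c3[nH]2)cc1OC`, gives 22.5 nM.
Compound 2, `Cn1c(=O)c2nc(-c3ccc(Cl)cc3)[nH]c2n(C)c1=O`, gives 0.8 nM.

Both were measured in an assay for binding affinity to adenosine receptor A1 (Bos taurus); on this read-out lower numbers stand for stronger inhibition and higher numbers for weaker inhibition. Among the compounds with values here, compound 2 holds the lowest of the two numbers; compound 1 is its only neighbour, and the gap between them lies beyond the scatter. Compound 3, `Cn1c(=O)c2nc(-c3ccc(I)cc3)[nH]c2n(C)c1=O`, has not yet been measured in this assay. It differs from compound 2 by iodo in place of chloro on an aromatic carbon. Within the data shown here, no pair of measured compounds shows a step of this kind, so its size is unknown from these data; a step within the scatter, in no fixed direction, is expected. For compound 3 the estimate is 1 nM, within 0.3 nM to 3.5 nM. This expected value corresponds to a step of a 1.3-fold higher number from compound 2 to compound 3 (0.10 log units; within the scatter).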

Compound 3, half-maximal inhibitory concentration: 1.3 nM
Beside the measured number, compound 3's estimate is 1.3-fold (0.11 log units) below it; measured number inside the range.
By their numbers in this assay, from the lowest: compounds 2 and 3 (each within the scatter of the next); then compound 1.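

In this assay, iodo in place of chloro on the aromatic carbon para to a large group comes to a 1.6-fold higher number from compound 2 to compound 3 (0.21 log units; within the scatter), so at this position the two halogens cannot be told apart. The earlier compounds shown here differed in more than one place and gave no reading of this position alone. Nothing shown explains this likeness between chloro and iodo.

On these data alone, whether an amine, a carboxylic acid or a longer chain at this position would give a number in the same range remains open. So does the outcome of the same exchange on another core.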